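The source may report more compounds than this note shows. Statements on the series, on what has been measured and on what is new or still open speak of the compounds shown alone.

Compound 1, `O=C(Nc1ccc(Cl)cc1)c1cc(=O)[nH]c2cc(Br)ccc12`: in a functional assay on KYSE-410 cells (Homo sapiens) for antiproliferative activity, read by MTT assay, with a stated time of 72 h (on this read-out lower numbers stand for stronger inhibition and higher numbers for weaker inhibition), compound 1 gives only a limit, > 20000 nM.
Compound 2, `O=C(Nc1cc(F)cc(F)c1)c1cc(=O)[nH]c2cc(Br)ccc12`: compound 2 gives 11200 nM.
Compound 3, `O=C(Nc1cccc(F)c1)c1cc(=O)[nH]c2cc(-c3ccc(F)cc3)ccc12`: compound 3 gives 10300 nM.

In this assay the numbers of compound 3 and compound 2 lie within the usual scatter of each other, so neither can be ranked over the other; compound 1 contributes a limit rather than a number. Compound 4, `C=Cc1ccc2c(C(=O)Nc3cccc(F)c3)cc(=O)[nH]c2c1`, has not yet been measured. It differs from compound 3 in one place: vinyl in place of 4-fluorophenyl on an aromatic carbon. No measured pair touches this position, so nothing shown speaks to the size or direction of this change. Compound 4 is therefore expected to stay close to compound 3, with a step of a 1.5-fold higher number from compound 3 to compound 4 (0.16 log units; within the scatter), and its estimated value in this assay is 15000 nM, within a range from 4000 nM to 60000 nM.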

Compound 4, half-maximal inhibitory concentration: 13600 nM
The estimate for compound 4 lay 1.1-fold (0.04 log units) above the measured number; the range from low to high includes it.
By their numbers in this assay, from the lowest: compounds 3, 2 and 4 (each within the scatter of the next). At a limit, above all of these: compound 1.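

In this assay, putting vinyl in place of 4-fluorophenyl on this aromatic carbon gives a 1.3-fold higher number from compound 3 to compound 4 (0.12 log units; within the scatter). The aromatic ring of the leaving group is therefore not required to hold the number at this level, and a far smaller group serves equally well here. Compound 1 gives a limit rather than a number, so the scale ends not far from these values: the limit of > 20000 nM in this assay, at which 1 of the 4 values shown sits.

Going by these compounds, whether an amine or a carboxylic acid on this carbon would move the number beyond the scatter stays open. So does whether any group here can bring a clearly lower number.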